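Fluorinated carbonyl substituents on the piperidine-linked series

This account rests on a few compounds, and the source may have more. Where it says the series, first, only, none or still open, it means among the compounds named here.

Measured so far:
compound 1 `Cc1nc(S(C)(=O)=O)ccc1Oc1ncnc(OC2CCN(C(=O)OC(C)(C)C(F)(F)F)CC2)c1F` — 47.2 nM
compound 2 `Cc1nc(S(C)(=O)=O)ccc1Oc1ncnc(OC2CCN(C(=O)O[C@@H](C)CF)CC2)c1F` — 1680 nM
compound 3 `Cc1nc(S(C)(=O)=O)ccc1Oc1ncnc(OC2CCN(C(=O)SC(C)(C)C)CC2)c1F` — 30.7 nM

In a functional assay on isolated protein for inhibition of Glucose-dependent insulinotropic receptor (Rattus norvegicus), read by HTRF and cAMP accumulation (on this read-out higher numbers stand for an effect only at larger amounts of compound and lower numbers for an effect already at smaller amounts), compound 3 gives the lowest of the three numbers. Compound 1 sits close by, since a 1.5-fold lower number from compound 1 to compound 3 (0.19 log units; within the scatter); compound 2 is far off, as a 55-fold lower number from compound 2 to compound 3 (1.74 log units; beyond the scatter) shows. The large gap among the measured compounds comes from the oxygen-linked groups: a 36-fold higher number from compound 1 to compound 2 (1.55 log units; beyond the scatter).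

Compound 4 `CCC(F)(F)C(=O)N1CCC(Oc2ncnc(Oc3ccc(S(C)(=O)=O)nc3C)c2F)CC1` has not yet been measured in this assay. Its change from compound 3: 1,1-difluoropropyl in place of (tert-butyl)sulfanyl on a carbonyl carbon. Among the compounds with values here, no measured pair covers a carbon-linked group on the carbonyl carbon, so the bearing steps are indirect. The exchange of the sulfur-linked group for the oxygen-linked fluorinated group was small, a 1.5-fold lower number from compound 1 to compound 3 (0.19 log units; within the scatter), while the smaller fluorinated group gave a large loss, a 36-fold higher number from compound 1 to compound 2 (1.55 log units; beyond the scatter). The entering 1,1-difluoropropyl is of similar size to both leaving groups, so a modest rise in number is expected, with wide uncertainty: compound 4 is estimated at 110 nM, between 30 nM and 450 nM, a step of a 3.6-fold higher number from compound 3 to compound 4 (0.55 log units; beyond the scatter).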

Compound 4, half-maximal effective concentration: 69.2 nM
Estimate against measurement, compound 4: 1.6-fold (0.20 log units) above; low and high end bracket the measured number.
By their numbers in this assay, from the lowest: compounds 3, 1 and 4 (each within the scatter of the next, the first and the last beyond it); then compound 2.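

In this assay a carbon-linked group on the carbonyl carbon holds up well: a 1.5-fold higher number from compound 1 to compound 4 (0.17 log units; within the scatter) is the step against the oxygen-linked 1-methyl-1-(trifluoromethyl)ethoxy group, while a 2.3-fold higher number from compound 3 to compound 4 (0.35 log units; beyond the scatter) is a modest loss against the sulfur-linked (tert-butyl)sulfanyl. Within the data shown here, the step of a 24-fold lower number from compound 2 to compound 4 (1.39 log units; beyond the scatter) leaves compound 2 as the only high number, so oxygen, sulfur and carbon links all occur among the low numbers, and compound 2, oxygen-linked like compound 1, goes against any reading by link atom alone. No available data explain these steps.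

Open, as far as these compounds go, is whether a longer chain than 1,1-difluoropropyl on the carbonyl carbon keeps the number in this range. Also open, from the compounds shown here alone, is how an unfluorinated propyl group or an amine at the same place, which would give a urea, compares.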